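The source may report more compounds than this note shows. Statements on the series, on what has been measured and on what is new or still open speak of the compounds shown alone.

Of the compounds shown here, three built on a shared core have been tested so far, and they differ only in one group on an aromatic ring. In a functional assay on MCF7 cells (Homo sapiens) for inhibition, read by MTT assay, with a stated time of 72 h (on this read-out higher numbers stand for weaker inhibition and lower numbers for stronger inhibition), compound 1 `COc1ccc(-c2nnc(SCCCN3CCN(c4nc5ccccc5s4)CC3)o2)cc1` gives 171000 nM, compound 2 `O=[N+]([O-])c1ccc(-c2nnc(SCCCN3CCN(c4nc5ccccc5s4)CC3)o2)cc1` gives 118000 nM and compound 3 `CC(C)(C)Oc1ccc(-c2nnc(SCCCN3CCN(c4nc5ccccc5s4)CC3)o2)cc1` gives 89300 nM. Compound 3 therefore cannot be told apart from the other two: a 1.9-fold lower number from compound 1 to compound 3 (0.28 log units; within the scatter) and a 1.3-fold lower number from compound 2 to compound 3 (0.12 log units; within the scatter) both stay within the scatter, as does a 1.4-fold lower number from compound 1 to compound 2 (0.16 log units; within the scatter).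

Compound 4 `O=C(NCc1nnc(SCCCN2CCN(c3nc4ccccc4s3)CC2)o1)c1ccccc1` departs further from this set. It carries benzamidomethyl in place of 4-(tert-butoxy)phenyl on an aromatic carbon of the five-membered aromatic ring with 2 nitrogen and 1 oxygen: benzamidomethyl in place of 4-(tert-butoxy)phenyl on an aromatic carbon.

For the measured compounds named here, the three measured steps are the only guide, and they bear on this change only loosely. Each swaps a group on the aromatic ring, whereas this change replaces the whole group that holds that ring. Going by the values given here, no measured compound shows such a replacement. Swapping groups in compound 3 and its two relatives moved the number by no more than a 1.9-fold lower number from compound 1 to compound 3 (0.28 log units; within the scatter), so no step beyond the scatter is expected in this assay, in either direction, though with wide uncertainty. The expected step is a 1.1-fold higher number from compound 3 to compound 4 (0.05 log units; within the scatter). For compound 4 the estimate is 100000 nM, with an expected range from 40000 nM to 250000 nM.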

Compound 4, half-maximal inhibitory concentration: 39000 nM
Estimate against measurement, compound 4: 2.6-fold (0.41 log units) above, outside the stated range (below it).
By their numbers in this assay, from the lowest: compound 4; then compounds 3, 2 and 1 (each within the scatter of the next).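

In this assay, for the compounds shown here, replacing the whole group on this carbon of the five-membered ring gives the first steps in the set that lie beyond the scatter: a 2.3-fold lower number from compound 3 to compound 4 (0.36 log units; beyond the scatter) and a 3.0-fold lower number from compound 2 to compound 4 (0.48 log units; beyond the scatter) and a 4.4-fold lower number from compound 1 to compound 4 (0.64 log units; beyond the scatter), all of them modest. Swapping groups on the outer aromatic ring had left compounds 1, 2 and 3 within the scatter of one another, whereas this position responds to exchanging 4-(tert-butoxy)phenyl for benzamidomethyl, and compound 4 now has the lowest number of the four, with steps to all the others beyond the scatter. The entering group keeps a six-membered aromatic ring of carbon only but adds a double bond outside aromatic rings and a hydrogen-bond donor, and no measurement at hand shows which of these differences, if any, accounts for the step.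

The amide and the chain that holds it enter together, so the compounds shown cannot say which of them goes with the lower number. An aminomethyl group on this carbon would test the chain without the benzoyl part, and a longer chain between the amide and the five-membered ring or a carboxylic acid on the benzamide ring would show how far the change can be taken.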